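This account rests on a few compounds, and the source may have more. Where it says the series, first, only, none or still open, it means among the compounds named here.

Working notes on the group on the sulfonyl sulfur, read in an ADME assay on Vero cells (Chlorocebus sabaeus) for cytotoxicity, read by MTT assay; a higher number here means that more compound is tolerated, a lower number that less compound is tolerated. Compound 3 `Cn1nc(C(F)(F)F)cc1C(=O)Nc1ccc(S(=O)(=O)N2CCC(N)CC2)cc1` gives > 300000 nM, which is a limit and not a number. Compound 1 `Cn1nc(C(F)(F)F)cc1C(=O)Nc1ccc(S(=O)(=O)N2CCCCC2)cc1` gives > 300000 nM, also a limit. Among the measured compounds shown here, compound 2 `Cn1nc(C(F)(F)F)cc1C(=O)Nc1ccc(S(=O)(=O)n2ccc3ccccc32)cc1` gives 13000 nM, the one true number. Compound 3 therefore stands at the limit of > 300000 nM in this assay, at which 2 of the 3 values shown sit.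

The next structure is compound 4 `Cn1nc(C(F)(F)F)cc1C(=O)Nc1ccc(S(=O)(=O)N2CCCCC2CO)cc1`, with 2-(hydroxymethyl)piperidin-1-yl in place of 4-aminopiperidin-1-yl on a sulfonyl sulfur. Two measured steps are large, an at least 23-fold lower number from compound 1 to compound 2 (1.36 log units; beyond the scatter) and an at least 23-fold higher number from compound 2 to compound 3 (1.36 log units; beyond the scatter), and both involve the 1H-indol-1-yl group. For the measured compounds named here, the third, a step that the two limits leave unreadable from compound 1 to compound 3, cannot be sized, although it is the closest precedent for a change on the saturated ring. Compound 4 has no 1H-indol-1-yl group and keeps a six-membered non-aromatic ring, as compound 1 and compound 3 do. The expected result is an at least 1.2-fold lower number from compound 3 to compound 4 (0.07 log units; that floor lies within the scatter), with no change beyond the scatter in this assay, and another limit is quite possible. The estimate for compound 4 is 250000 nM, with an expected range of 100000 nM to 300000 nM.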

Compound 4, half-maximal cytotoxic concentration: 159000 nM
Compound 4: middle estimate off by 1.6-fold (0.20 log units), on the high side; low and high end bracket the measured number.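

In this assay, among the compounds shown here, compound 4 is the only compound with a saturated ring on the sulfonyl sulfur that gives a true number and not a limit. That number still stands well clear of the 1H-indol-1-yl compound, with a 12-fold higher number from compound 2 to compound 4 (1.09 log units; beyond the scatter), so all three saturated-ring compounds now lie beyond the scatter on the same side of compound 2. Against the other two only floors can be given, an at least 1.8-fold lower number from compound 3 to compound 4 (0.27 log units; that floor lies within the scatter) and an at least 1.8-fold lower number from compound 1 to compound 4 (0.27 log units; that floor lies within the scatter), and neither shows a change beyond the scatter because compound 1 and compound 3 each rest on a limit: the limit of > 300000 nM in this assay, at which 2 of the 4 values shown sit.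

On these data alone, whether a carboxylic acid or a longer chain in place of hydroxymethyl on the saturated ring would give a similar number stays open. So does whether an aromatic group other than 1H-indol-1-yl on the sulfonyl sulfur would fall as low as compound 2.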